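Opening a Ring: Expecting the Diol Analogue, Compound 4

This account rests on a few compounds, and the source may have more. Where it says the series, first, only, none or still open, it means among the compounds named here.

Of the compounds shown here, three sharing one core have been tested in a functional assay on the whole organism (strain Albino Wistar) for inhibition, with Rattus norvegicus as the target, read by paw edema, with stated times of 1 h and 5 h, at a dose of 10 mg/kg by the oral route; a lower number here means less inhibition, a higher number more inhibition at the dose given (going by the name of the read-out). Compound 1 `Clc1cccc(-n2cc(CSc3nc4ccccc4s3)nn2)c1` gives 39.6%. Compound 2 `Brc1ccc(-n2cc(CSc3nc4ccccc4s3)nn2)cc1` gives 59.2%. Compound 3 `CC1(C)OCC(Cn2cc(CSc3nc4ccccc4s3)nn2)O1` gives 49.1%, the second highest of the three numbers: its nearest neighbour is compound 1, within the scatter, and its furthest is compound 2, beyond the scatter. All measured steps swap the whole group on the aromatic nitrogen: a number 19.6 percentage points higher from compound 1 to compound 2 (beyond the scatter), a number 9.5 percentage points higher from compound 1 to compound 3 (within the scatter), and a number 10.1 percentage points lower from compound 2 to compound 3 (beyond the scatter).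

Compound 4 `OCC(O)Cn1cc(CSc2nc3ccccc3s2)nn1` keeps the chain of compound 3 but loses its ring: 1,2-dihydroxyethyl in place of 2,2-dimethyl-1,3-dioxolan-4-yl on a saturated chain carbon bound to an aromatic nitrogen. Within the data shown here, no measured step alters this part of the molecule while leaving everything else untouched, so none bears directly on the change; the three known steps only show that exchanging the group on the aromatic nitrogen moves this assay by modest amounts, from within the scatter to somewhat beyond it. Without a direct guide, the step is expected to remain within the scatter: a number 2.1 percentage points lower from compound 3 to compound 4 (within the scatter). Compound 4 is therefore estimated at 47% in this assay, with a range from 30% to 64%, the width reflecting the lack of a matching precedent.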

Compound 4, a percentage reported as inhibition, in the whole organism at one dose (the size of the read-out at that dose, not a potency): 52.8%
Estimate against measurement, compound 4: 5.8 percentage points below, within the range that was stated.
By their numbers in this assay, from the lowest: compounds 1, 3, 4 and 2 (each within the scatter of the next, the first and the last beyond it).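

In this assay, the closed ring of compound 3 can be exchanged for the open 1,2-dihydroxyethyl group, which carries hydrogen-bond donors where the ring carries none, and this gives a number 3.7 percentage points higher from compound 3 to compound 4 (within the scatter), so this first change made within the group on the aromatic nitrogen does not separate the two compounds. The comparison with the aryl compounds also shifts: there is a number 6.4 percentage points lower from compound 2 to compound 4 (within the scatter), whereas the step to compound 3 from the 4-bromophenyl compound lay beyond the scatter, and there is a number 13.2 percentage points higher from compound 1 to compound 4 (beyond the scatter), whereas the step to compound 3 from the 3-chlorophenyl compound lay within it. No measurement here explains why the open and closed forms read so alike, or what the hydroxyl groups contribute to the result.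

The compounds shown leave open how an amine or a carboxylic acid at the end of this chain would read, and whether a longer chain carrying the same hydroxyl groups would stay within the scatter of compound 4. As far as these compounds go, each number also comes from a single oral dose, so how compound 3 and compound 4 would compare at other doses remains unknown.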